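The source may report more compounds than this note shows. Statements on the series, on what has been measured and on what is new or still open speak of the compounds shown alone.

Compound 1 `CC(=O)OC[C@H]1O[C@H](OC[C@@H](Cn2cc(CN(c3nc(-c4cccc([N+](=O)[O-])c4)no3)C3CCCCC3)nn2)OC(C)=O)C=C[C@@H]1OC(C)=O`: 100 ug/mL
Compound 2 `C#CCN(c1nc(-c2ccccc2)no1)C1CCCCC1`: 32.1 ug/mL
Compound 3 `CC(=O)OC[C@H]1O[C@H](OC[C@@H](Cn2cc(CN(c3nc(-c4ccc(Br)cc4)no3)C3CCCCC3)nn2)OC(C)=O)C=C[C@@H]1OC(C)=O`: 39.1 ug/mL

In an ADME assay on RAW264.7 cells (Mus musculus) for cytotoxicity, read by MTT assay, with a stated time of 48 h (a lower number here means that less compound is tolerated, a higher number that more compound is tolerated), compound 2 sits at the low end of these numbers: its gap to compound 3 lies within the scatter, while compound 1 tolerates clearly more. Going by the values given here, the one measured step, a 2.6-fold lower number from compound 1 to compound 3 (0.41 log units; beyond the scatter), swaps a group on the phenyl ring and shifts the number only modestly. Compound 4 `C#CCN(c1nc(-c2ccc(C#C)cc2)no1)C1CCCCC1` differs from compound 2 by ethynyl in place of hydrogen on an aromatic carbon, a small addition to the phenyl ring of the same kind of place. Among the compounds with values here, with only that modest precedent, a step of a 1.1-fold lower number from compound 2 to compound 4 (0.03 log units; within the scatter) is expected, that is, no change beyond the scatter. Compound 4 is therefore estimated at 30 ug/mL, with a range from 12 ug/mL to 75 ug/mL.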

Compound 4, half-maximal cytotoxic concentration: 13.1 ug/mL
Compound 4: the middle estimate sits 2.3-fold (0.36 log units) above what was measured, and the stated range covers the measured number.
By their numbers in this assay, from the lowest: compound 4; then compounds 2 and 3 (each within the scatter of the next); then compound 1.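

In this assay, ethynyl in place of hydrogen gives a 2.5-fold lower number from compound 2 to compound 4 (0.39 log units; beyond the scatter), so less compound is tolerated. Even this small group of 2 heavy atoms, on an aromatic carbon para to a large group, moves the number beyond the scatter. Nothing measured here explains this drop. The compounds shown leave open whether the drop belongs to ethynyl itself or to any group at this place, which a methyl, an amine or a carboxylic acid on the same carbon would help to separate. Going by these compounds, whether ethynyl acts alike on the larger compound 3 also stays open.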